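Amide series: chloro to methoxy on the benzyl group

This account rests on a few compounds, and the source may have more. Where it says the series, first, only, none or still open, it means among the compounds named here.

Compound 1 `COc1ccc(CNC(=O)CSc2nc3ccc(NC(=O)c4ccccc4)cc3s2)cc1` gives 12700 nM in a functional assay on HepG2 cells (Homo sapiens) for cytotoxicity, read by MTT assay, with a stated time of 48 h; on this read-out lower numbers stand for stronger inhibition and higher numbers for weaker inhibition. Compound 2 `O=C(CSc1nc2ccc(NC(=O)c3ccc([N+](=O)[O-])cc3)cc2s1)NCc1ccc(Cl)cc1` is recorded in this assay only as a limit, at > 100000 nM. Compound 2 thus sits at the limit of > 100000 nM in this assay, at which 1 of the 2 values shown sits. Compound 3 `COc1ccc(CNC(=O)CSc2nc3ccc(NC(=O)c4ccc([N+](=O)[O-])cc4)cc3s2)cc1` is not yet measured; relative to compound 2 it carries methoxy in place of chloro on an aromatic carbon. Among the measured compounds shown here, no measured step joins compound 2 and compound 3, and compound 1 and compound 2 differ in more than one place, so the size of this change is open. For compound 3 the expected step is an at least 1.6-fold lower number from compound 2 to compound 3 (0.22 log units; that floor lies within the scatter), toward stronger inhibition. Compound 3 is estimated at 60000 nM, within 15000 nM to 200000 nM.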

Compound 3, half-maximal inhibitory concentration: > 100000 nM
Compound 3: only a limit was reported; the forecaster's own chance of this, stated with the estimate: 50%; middle value at least 1.6-fold (0.22 log units) from the limit.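

Compound 3 stays at a limit of the assay, as compound 2 does, and the step between them cannot be read: the limit of > 100000 nM in this assay, at which 2 of the 3 values shown sit. Among the compounds shown here, with the 4-methoxybenzyl group kept, nitro in place of hydrogen on an aromatic carbon gives the first readable step, an at least 7.8-fold higher number from compound 1 to compound 3 (0.89 log units; beyond the scatter), so the nitro compounds shown sit at the limit whichever benzyl group they carry. Open, from the compounds shown here alone, is whether chloro and methoxy differ at all on the benzyl group once the nitro is absent, and how an amine or a carboxylic acid in place of nitro would read.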